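The compounds below may be only part of what the source reports. "The series", "measured", "known", "first", "only" and "open" are said of these compounds alone.

Measured so far:
- compound 1 `N#CC1=C(N)OC(c2c[nH]c3ccccc23)=C(C#N)C1c1ccc2ccccc2c1`: "not active" (no number reported)
- compound 2 `N#CC1=C(N)OC(c2c[nH]c3ccccc23)=C(C#N)C1c1ccccc1Cl`: 10.4%

In a functional assay, tested at 100 ug/mL (a lower number here means a weaker effect, a higher number a stronger effect of the compound at the concentration tested), compound 2 gives 10.4%, a small effect. Compound 1 is reported in this assay only as "not active" (no number reported), without a number. Within the data shown here, compound 2 therefore stands as the only compound with a number, and that number is low. Compound 3 `N#CC1=C(N)OC(c2c[nH]c3ccccc23)=C(C#N)C1c1cccc2ccccc12` has not yet been measured. Compared with compound 2, the change is naphthalen-1-yl in place of 2-chlorophenyl on a saturated ring carbon. Among the measured compounds shown here, no step between two measured compounds is available, so nothing measured shows how such a change plays out. Since compound 2 gives 10.4% and compound 1 gives "not active" (no number reported), a weak read-out is expected for compound 3 as well, with the step of a number 2.4 percentage points lower from compound 2 to compound 3 (within the scatter) expected to lie within the usual scatter. The estimate for compound 3 in this assay is 8%, in a range from 0% to 20%.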

Compound 3, a percentage reported as activity, at one concentration (the size of the read-out at that concentration, not a potency): 6.8%
Compound 3: the middle estimate sits 1.2 percentage points above what was measured, and the stated range covers the measured number.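

In this assay, among these compounds, placing naphthalen-1-yl instead of 2-chlorophenyl on the saturated ring carbon gives a number 3.6 percentage points lower from compound 2 to compound 3 (within the scatter), the first measured step at this position. Going from one aromatic ring carrying chlorine to two aromatic rings of carbon only, and from 7 to 10 heavy atoms, therefore does not move the read-out beyond ordinary repeat-to-repeat variation, and the effect stays small at the single concentration tested. Nothing available explains this result.

On these data alone, both groups at this position are aromatic and carry no hydrogen-bond donors or acceptors, so it remains open whether a phenyl ring bearing an amine or a carboxylic acid would give a clearly larger read-out. A longer carbon chain in place of the aromatic group is equally untested among the compounds shown here.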